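Swapping acetyl for methylsulfonyl on the amine nitrogen

This account rests on a few compounds, and the source may have more. Where it says the series, first, only, none or still open, it means among the compounds named here.

Measured compounds:
Compound 1 `CC(=O)N[C@@H]1CCCc2c1cncc2N1C(=O)c2ccc(Cl)cc2[C@@H]1C` gives 4 nM in an assay on cells for inhibition of cytochrome P450 11B2, mitochondrial (Homo sapiens), read by HTRF; on this read-out higher numbers stand for weaker inhibition and lower numbers for stronger inhibition.
Compound 2 `CC(=O)N[C@@H]1CCCc2c1cncc2N1Cc2cc(Cl)ccc2C1=O` gives 44 nM.
Compound 3 `CC(=O)N[C@@H]1CCCc2c1cncc2N1C(=O)c2ccc(Cl)cc2[C@H]1C1CC1` gives 100 nM.

Of these three numbers, compound 2 holds the second highest. Its nearest neighbour is reached by a 2.3-fold higher number from compound 2 to compound 3 (0.36 log units; beyond the scatter), and its furthest by an 11-fold higher number from compound 1 to compound 2 (1.04 log units; beyond the scatter). Both of these measured steps change a group on a saturated ring carbon of the shared core.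

Compound 4 `CS(=O)(=O)N[C@@H]1CCCc2c1cncc2N1Cc2cc(Cl)ccc2C1=O` differs from compound 2 in another place: methylsulfonyl in place of acetyl on an amine nitrogen. Among the compounds with values here, no measured step touches the amine nitrogen, so the two known steps give no direct guide to this change; they show only that the series can move over a wide span of numbers. With nothing pointing in either direction, the expected step is small, possibly within the scatter, with a wide range around it.

Compound 4 is therefore estimated at 60 nM, with a range from 20 nM to 200 nM. This estimate means a 1.4-fold higher number from compound 2 to compound 4 (0.13 log units; within the scatter) is expected.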

Compound 4, half-maximal inhibitory concentration: 998 nM
For compound 4 the middle estimate is 17-fold (1.22 log units) below the measured one, and the stated range ends below it.
By their numbers in this assay, from the lowest: compound 1; then compound 2; then compound 3; then compound 4.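

The amine nitrogen turns out to be a sensitive place in the series: in this assay, methylsulfonyl in place of acetyl gives a 23-fold higher number from compound 2 to compound 4 (1.36 log units; beyond the scatter), a large step of the same order as the one on the saturated ring carbon, an 11-fold higher number from compound 1 to compound 2 (1.04 log units; beyond the scatter). Acetamido and methanesulfonamido are therefore far from interchangeable on this core, and compound 4 now holds the highest number of the four compounds. No measurement shown gives a reason for the size of this step.

As far as these compounds go, whether the same swap would move the number as far on the core of compound 1 remains open. So does the effect of other groups on this nitrogen, such as a propanoyl group, a longer acyl chain or a urea.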